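Swapping the sulfonyl aryl group from compound 2 to compound 3

The source may report more compounds than this note shows. Statements on the series, on what has been measured and on what is new or still open speak of the compounds shown alone.

Of the compounds shown here, two with the same core have been measured so far. Compound 1 `O=S(=O)(c1ccc(F)c(Cl)c1)c1cnc2cc(F)ccc2c1-c1ccc(Cl)cc1` is tested in an ADME assay on microsomes from liver (Homo sapiens) for metabolic stability, tested at 2.5 uM (a lower number here means slower removal, a higher number faster removal of the compound), and gives 0.39 mL/min. Compound 2 `Cc1ccc(S(=O)(=O)c2cnc3cc(F)ccc3c2-c2cccc(Cl)c2)cc1C` is also tested in this assay, and compound 2 gives 4.01 mL/min. Of these two numbers, compound 2 has the higher one, and the gap to compound 1 is beyond the usual scatter, so compound 2 is removed faster of the two.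

Compound 3 `O=S(=O)(c1ccc(F)c(Cl)c1)c1cnc2cc(F)ccc2c1-c1cccc(Cl)c1` has not yet been measured. Compared with compound 2, the difference is 3-chloro-4-fluorophenyl in place of 3,4-dimethylphenyl on a sulfonyl sulfur. The group that enters is the same group that compound 1 carries on its sulfonyl sulfur, and the two compounds differ elsewhere only in the position of a chlorine on the other aryl ring.

Because compound 1 gives 0.39 mL/min, a clearly lower number than compound 2, the expected step from compound 2 to compound 3 in this assay is a drop of about a 6.7-fold lower number from compound 2 to compound 3 (0.82 log units; beyond the scatter). The estimate for compound 3 in this assay is therefore 0.6 mL/min, with a range from 0.25 mL/min to 1.5 mL/min.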

Compound 3, intrinsic clearance in a liver preparation (reported as CLH), per the amount of preparation that the assay uses: 0.66 mL/min
Compound 3: the middle estimate sits 1.1-fold (0.04 log units) below what was measured; the range from low to high includes it.
By their numbers in this assay, from the lowest: compounds 1 and 3 (each within the scatter of the next); then compound 2.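

Within the data shown here, with nothing else altered, 3-chloro-4-fluorophenyl in place of 3,4-dimethylphenyl on a sulfonyl sulfur gives a 6.1-fold lower number from compound 2 to compound 3 (0.78 log units; beyond the scatter) in this assay and this is the first comparison to tie a change beyond the scatter to this one place. Among these compounds, on the other aryl ring, 3-chlorophenyl in place of 4-chlorophenyl on an aromatic carbon gives a 1.7-fold higher number from compound 1 to compound 3 (0.23 log units; within the scatter) so that swap shows no real change in this assay and, of the two single changes seen so far, only the one on the sulfonyl sulfur moves the number beyond the scatter. Nothing measured here explains why the sulfonyl aryl swap has this effect.

Both methyl groups were replaced together, by a chlorine and a fluorine, so these compounds cannot show whether one of the new atoms alone accounts for the step or whether removing one methyl group would do the same. As far as these compounds go, it also remains open how a phenyl ring carrying only a fluorine or only a chlorine would behave at this place, or one carrying a methoxy group or a nitrile, and whether the step would be the same size with 4-chlorophenyl on the other ring.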